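Swapping cyano for nitro on the aromatic carbon

This account rests on a few compounds, and the source may have more. Where it says the series, first, only, none or still open, it means among the compounds named here.

In a functional assay on U-937 cells (Homo sapiens) for antiproliferative activity, with a stated time of 48 h (on this read-out lower numbers stand for an effect already at smaller amounts and higher numbers for an effect only at larger amounts of compound), three compounds built on one shared core have been measured so far. Compound 1 `Nc1ccc(NC(=O)CCCCCCC(=O)NO)cc1` gives 6400 nM, compound 2 `O=C(CCCCCCC(=O)Nc1ccc(O)cc1)NO` gives 6400 nM, and compound 3 `N#Cc1ccc(NC(=O)CCCCCCC(=O)NO)cc1` gives 7000 nM. Compound 3 therefore stands level with the other two, within the scatter of each.

The next compound, compound 4 `O=C(CCCCCCC(=O)Nc1ccc([N+](=O)[O-])cc1)NO`, carries nitro in place of cyano on an aromatic carbon, para to a large group: nitro in place of cyano on an aromatic carbon. All three measured steps changed the group at this same place. Hydroxy in place of amino gave no change at the digits printed from compound 1 to compound 2 (within the scatter), cyano in place of amino gave a 1.1-fold higher number from compound 1 to compound 3 (0.04 log units; within the scatter), and cyano in place of hydroxy gave a 1.1-fold higher number from compound 2 to compound 3 (0.04 log units; within the scatter). None of them left the scatter, so across these three compounds the read-out has not responded to the group at this place.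

No step beyond the scatter is therefore expected in this assay, in either direction. The expected step is a 1.0-fold lower number from compound 3 to compound 4 (0.01 log units; within the scatter). For compound 4 the estimated value is 6800 nM, with an expected range from 3500 nM to 13000 nM.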

Compound 4, half-maximal effective concentration: 22000 nM
The estimate for compound 4 lay 3.2-fold (0.51 log units) below the measured number, and the stated range ends below it.
By their numbers in this assay, from the lowest: compounds 1, 2 and 3 (each within the scatter of the next); then compound 4.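

In this assay, the place on the aromatic carbon para to a large group proves not to be indifferent to every group: nitro in place of cyano gives a 3.1-fold higher number from compound 3 to compound 4 (0.50 log units; beyond the scatter), nitro in place of hydroxy gives a 3.4-fold higher number from compound 2 to compound 4 (0.54 log units; beyond the scatter), and nitro in place of amino gives a 3.4-fold higher number from compound 1 to compound 4 (0.54 log units; beyond the scatter). Going by these compounds alone, the steps are modest, but nitro is the one group of the four that stands apart, so the flat picture from amino, hydroxy and cyano held for those three groups only. Nothing measured alongside these compounds bears on why this happens.

From the compounds shown here alone, it remains open whether the higher number belongs to nitro alone or would also appear with a carboxylic acid, a methyl ester or trifluoromethyl at this place. Going by these compounds, it is also open whether the same step would appear with a longer chain in the shared core.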